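The source may hold more compounds than are shown below. What is called first, only, known or untested is meant among the compounds shown, and "the series" means these compounds.

In an assay on HEK293 cells for positive allosteric modulation of metabotropic glutamate receptor 2 (Rattus norvegicus), read by thallium flux, with a stated time of 2.5 min (on this read-out lower numbers stand for smaller maximal responses and higher numbers for larger maximal responses), the two measured compounds are:

- compound 1 `Cc1ccc(C(=O)O)cc1OCCCCOc1ccc(C(=O)CC2CCCC2)c(O)c1C`, which gives 67.5%
- compound 2 `CC(=O)c1ccc(OCCCCOc2ccc(C(=O)O)cc2C)c(C)c1O`, which gives 83.1%

Compound 2 stands highest of these two numbers, with compound 1 beyond the scatter below it. Compound 3 `Cc1cc(C(=O)O)ccc1OCCCCOc1ccc(C(=O)CC2CCCC2)c(O)c1C` has not yet been measured; it differs from compound 2 by cyclopentyl in place of hydrogen on a saturated chain carbon bound to a carbonyl carbon. Compound 1 also carries cyclopentyl at that place and gives only 67.5%, so a downward step beyond the scatter is expected, although the cores also differ elsewhere. The expected step is a number 12.1 percentage points lower from compound 2 to compound 3 (beyond the scatter). Compound 3 is estimated at 71%, with a range from 55% to 87%.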

Compound 3, largest response reached (reported as percent of maximum), in percent of the reference or control that the assay uses: 84.6%
Compound 3: the middle estimate sits 13.6 percentage points below what was measured, within the range that was stated.
By their numbers in this assay, from the lowest: compound 1; then compounds 2 and 3 (each within the scatter of the next).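

In this assay, cyclopentyl in place of hydrogen on a saturated chain carbon bound to a carbonyl carbon gives a number 1.5 percentage points higher from compound 2 to compound 3 (within the scatter) and so no change that stands out from the scatter. This chain position therefore accepts the five-membered ring. The lower number of compound 1 goes instead with the other place, where 4-carboxy-2-methylphenyl in place of 5-carboxy-2-methylphenyl gives a number 17.1 percentage points higher from compound 1 to compound 3 (beyond the scatter) as a clear step.

On these data alone, whether an amine or a longer chain at the same carbon would also leave the response unchanged stays open. Nothing measured here gives a reason for either step.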